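Swapping the Alkynyl Group on an Aromatic Carbon

A few compounds are considered here, and "the series" means these few. Any claim that something is new, unique, unknown or untested is made for them only; others in the source may bear on it.

Measured in an ADME assay on L1210/0 cells (Mus musculus) for cytotoxicity, with a stated time of 48 h; a higher number here means a weaker inhibitor, a lower number a stronger inhibitor:
- Compound 1 `N#CSc1cn([C@H]2C[C@H](O)[C@@H](CO)O2)c(=O)[nH]c1=O`: 78900 nM
- Compound 2 `CCCC#Cc1cn([C@H]2C[C@H](O)[C@@H](CO)O2)c(=O)[nH]c1=O`: > 200000 nM (a limit, not a number)

Compound 2 has no number of its own, only the limit of > 200000 nM in this assay. Compound 3 `O=c1[nH]c(=O)n([C@H]2C[C@H](O)[C@@H](CO)O2)cc1C1SCCS1` differs from it on an aromatic carbon of the shared core: a group of 5 heavy atoms (3 carbon, 2 sulfur; one five-membered non-aromatic ring with 2 hetero atoms) in place of a group of 5 heavy atoms (5 carbon; no ring), on an aromatic carbon. Within the data shown here, one measured step bears on this change, an at least 2.5-fold higher number from compound 1 to compound 2 (0.40 log units; beyond the scatter), which also exchanges one group for another on an aromatic carbon. That step shows that such an exchange can move the number beyond the scatter in the compounds 1 and 2, but it gives no size or direction for the new group with its five-membered non-aromatic ring. Only a small move towards a lower number is therefore expected, and compound 3 may well end at the same limit, given (the limit of > 200000 nM in this assay, at which 1 of the 2 values shown sits). The estimated change is an at least 1.3-fold lower number from compound 2 to compound 3 (0.12 log units; that floor lies within the scatter). For compound 3 the expected value is 150000 nM, with an estimated range from 60000 nM to 300000 nM.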

Compound 3, half-maximal inhibitory concentration: > 200000 nM
Compound 3: a limit, no number; the forecaster's own chance of this, stated with the estimate: 50%; middle value at least 1.3-fold (0.12 log units) away from the limit.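

In this assay compound 3 gives > 200000 nM, a limit and not a number, and compound 2 also stands at a limit, so the step between them cannot be read. The new information comes from the comparison with cyanosulfanyl: placing the group with the five-membered non-aromatic ring on this aromatic carbon gives an at least 2.5-fold higher number from compound 1 to compound 3 (0.40 log units; beyond the scatter), so a second group with no resemblance to pent-1-yn-1-yl in its ring count or its atoms also lies on the higher side of compound 1. At this position only compound 1 has a number, and compound 2 and compound 3 cannot be ranked against each other, as the readings gather at one ceiling: the limit of > 200000 nM in this assay, at which 2 of the 3 values shown sit.

Going by these compounds, it remains open whether a methyl group, a methylsulfanyl group or a plain nitrile on the same aromatic carbon would give a number rather than a limit. On these data alone, it is also open whether a five-membered ring with two oxygen atoms in place of the two sulfur atoms, or an open chain carrying those sulfur atoms, would read any differently from compound 3.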